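The source may report more compounds than this note shows. Statements on the series, on what has been measured and on what is new or still open speak of the compounds shown alone.

Measured so far in a functional assay on the whole organism (aorta) with Rattus norvegicus as the target; on this read-out higher numbers stand for larger maximal responses and lower numbers for smaller maximal responses:
compound 1 `CC1(C)C=C(n2ccccc2=O)c2cc(S(=O)(=O)Nc3ccccc3)ccc2O1` — 63.6%; 82.5% (2 entries)
compound 2 `CC1(C)C=C(n2ccccc2=O)c2cc(S(=O)(=O)c3ccccc3)ccc2O1` — 79.3%

Going by the values given here, compound 2 carries the only single number of the series in this assay, 79.3%; one further entry of compound 2 gives no single number. The repeated entries of compound 1, (the several entries of compound 1 in this assay, 63.6%; 82.5% (2 entries)), show how far two runs of this kind can drift apart.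

Compound 3 `CC1(C)C=C(n2ccccc2=O)c2cc(S(=O)(=O)Oc3ccccc3)ccc2O1` is the unmeasured partner of compound 2 and differs from it by phenoxy in place of phenyl on a sulfonyl sulfur. Among the compounds with values here, no measured pair carries this change, so no direction is set by the data; the expected step, a number 4.3 percentage points lower from compound 2 to compound 3 (within the scatter), is one not beyond the scatter. Compound 3 is estimated to reach 75%, with a range from 55% to 95%.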

Compound 3, largest response reached (Emax), in percent of the reference or control that the assay uses: 67.9%
Compound 3: the middle estimate sits 7.1 percentage points above what was measured, and the stated range covers the measured number.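

In this assay, the place on the sulfonyl sulfur now gives its first readable single change, phenoxy in place of phenyl: a number 11.4 percentage points lower from compound 2 to compound 3 (beyond the scatter). This shows that the response can shift with the group at this position, although the step rests on one pair. Its size needs caution, as repeated entries of one compound can lie far apart: the several entries of compound 1 in this assay, 63.6%; 82.5% (2 entries)

The compounds shown leave open whether the shift follows the linking oxygen itself or the phenoxy group as a whole. A benzyl group or a dimethylamine on the sulfonyl sulfur would test how general the step is.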